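This account rests on a few compounds, and the source may have more. Where it says the series, first, only, none or still open, it means among the compounds named here.

Compound 2 `CC(C)(C)c1nccn1CCC(C(N)=O)(c1ccccc1)c1ccccc1` is the reference point here. In an assay on ileum with muscarinic acetylcholine receptor M3 (Cavia porcellus) as the target (a higher number here means a weaker inhibitor, a lower number a stronger inhibitor), compound 2 gives 30.2 nM, the highest of the two numbers in hand. Going by the values given here, its nearest neighbour is compound 1 `CC(C)c1nccn1CCC(C(N)=O)(c1ccccc1)c1ccccc1`, which in this assay gives 1.8 nM; the only single-point step in the set, a 17-fold higher number from compound 1 to compound 2 (1.22 log units; beyond the scatter), runs from there to compound 2 and is large.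

Compound 3 `CCc1ncn(CCC(C(N)=O)(c2ccccc2)c2ccccc2)c1CC` keeps the shared core and the same atoms as compound 2, joined differently: 4,5-diethyl-1H-imidazol-1-yl in place of 2-(tert-butyl)-1H-imidazol-1-yl on a saturated chain carbon, three bonds along the chain from two aromatic carbons and a carbonyl carbon. Among the compounds with values here, no measured step covers a rearrangement of this kind; the one step available, a 17-fold higher number from compound 1 to compound 2 (1.22 log units; beyond the scatter), concerns only added methyl on the branch carbon of the substituent and bears on it indirectly at best. With the bulk moved off the carbon of the imidazole that was substituted in compound 2, the expectation is that compound 3 returns to a somewhat lower number, between compound 1 and compound 2. Compound 3 is accordingly estimated at 8 nM in this assay, within 2 nM to 35 nM, a change of a 3.8-fold lower number from compound 2 to compound 3 (0.58 log units; beyond the scatter) that is expected but uncertain.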

Compound 3, antagonist equilibrium constant: 3.98 nM
Estimate against measurement, compound 3: 2.0-fold (0.30 log units) above; the measured number falls inside the stated range.
By their numbers in this assay, from the lowest: compound 1; then compound 3; then compound 2.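

At this place on the chain, the atoms of the substituent alone do not set the number: 4,5-diethyl-1H-imidazol-1-yl and 2-(tert-butyl)-1H-imidazol-1-yl have the same heavy-atom count and composition, yet this assay records a 7.6-fold lower number from compound 2 to compound 3 (0.88 log units; beyond the scatter). The rearranged group does not fully match the 2-isopropyl-1H-imidazol-1-yl group, with a 2.2-fold higher number from compound 1 to compound 3 (0.34 log units; beyond the scatter), so the order runs from compound 1 through compound 3 to compound 2 in this small set. Nothing in the data on hand explains either step.

Still open is how far each ethyl group contributes to the number for compound 3, since a 1H-imidazol-1-yl bearing a single ethyl group is not among the compounds shown. Also unknown is how an open-chain amine in place of the imidazole would read in this assay at this place.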